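Solubility notes on the amide series

The compounds below may be only part of what the source reports. "The series", "measured", "known", "first", "only" and "open" are said of these compounds alone.

Measured so far:
compound 1 `NCc1csc(NC(=O)c2ncccn2)n1`: > 100 ug/mL
compound 2 `NCc1csc(NC(=O)c2cc3ccccc3[nH]2)n1`: > 100 ug/mL
compound 3 `NCc1csc(NC(=O)c2ccn[nH]2)n1`: > 100 ug/mL

All three readings come from a physicochemical assay for solubility, read by nephelometry, measured as kinetic solubility, at pH 2.0; on this read-out lower numbers stand for lower solubility and higher numbers for higher solubility. The value for compound 1 is a limit of the assay and not a number. The value for compound 2 is likewise a limit and not a number. The value for compound 3 is also a limit and not a number. Compound 2 therefore stands at the limit of > 100 ug/mL in this assay, at which 3 of the 3 values shown sit; nothing in the readings separates it from compound 1 or compound 3, and no order among the three can be drawn. Going by the values given here, since every measured compound sits at the same limit, no step between measured compounds can be quantified, and the series so far gives no measured step size to lean on.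

Compound 4 `NCc1csc(NC(=O)c2cc3ccccc3n2Cc2ccccc2)n1` is the next compound for this assay. Relative to compound 2 the change is benzyl in place of hydrogen on an aromatic nitrogen.

Expectation: a step downward in this assay, beyond the usual scatter, is estimated; the step from compound 2 to compound 4 is expected to be an at least 5.0-fold lower number from compound 2 to compound 4 (0.69 log units; beyond the scatter). For compound 4 the estimated solubility is 20 ug/mL, with a range from 5 ug/mL to 80 ug/mL. On these data alone, whether the reading again ends as a limit rather than a number remains open.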

Compound 4, solubility: 25 ug/mL
For compound 4 the middle estimate is 1.3-fold (0.10 log units) below the measured one; measured number inside the range.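

In this assay, going by these compounds alone, benzyl in place of hydrogen on an aromatic nitrogen gives an at least 4.0-fold lower number from compound 2 to compound 4 (0.60 log units; beyond the scatter), the first step that can be read at all, and it shows that this position can bring the read-out down to a number. The change is confined to one place on the shared core: a hydrogen leaves and a benzyl group of 7 heavy atoms enters, all carbon, with one six-membered aromatic ring and no hydrogen-bond donors or acceptors. The true size of the step remains unknown because compound 2 holds a limit and not a number: the limit of > 100 ug/mL in this assay, at which 3 of the 4 values shown sit.

On these data alone, whether a similar step needs the whole benzyl group remains open, since a methyl group or a short chain ending in an amine on the same nitrogen could separate the effect of the aromatic ring from that of simply replacing the hydrogen. Also open, as far as these compounds go, is whether a carboxylic acid or a hydroxyl group on the benzyl ring would move the reading of compound 4 in either direction.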